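This account rests on a few compounds, and the source may have more. Where it says the series, first, only, none or still open, it means among the compounds named here.

Working notes on the series, all values from a functional assay on QGY-7703 cells (Homo sapiens) for cytotoxicity, read by MTT assay, with a stated time of 24 h; a lower number here means a stronger inhibitor, a higher number a weaker inhibitor:

- compound 1 `COc1cc(/C=C2\CN(C)C/C(=C\c3cccnc3)C2=O)cc(OC)c1OC`: 4300 nM
- compound 2 `CN1C/C(=C\c2ccncc2)C(=O)/C(=C/c2ccc(C#N)cc2)C1`: 7400 nM
- compound 3 `O=C1/C(=C/c2cccnc2)CN(S(=O)(=O)c2ccccc2)C/C1=C\c1ccccc1F`: 4800 nM

Compound 3, at 4800 nM, lies within the scatter of compound 1 at 4300 nM and also within the scatter of compound 2 at 7400 nM. Within the data shown here, these three values therefore give no order among the compounds.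

The next compound to be read is compound 4 `O=C1/C(=C/c2cccnc2)CN(S(=O)(=O)c2ccc(C(F)(F)F)cc2)C/C1=C\c1ccccc1F`. Its structural difference from compound 3 is trifluoromethyl in place of hydrogen on an aromatic carbon, para to a large group, so that phenyl becomes 4-(trifluoromethyl)phenyl.

Among the measured compounds shown here, no pair of measured compounds differs in only one place, so the series offers no direct precedent for this change. The three measured compounds differ from one another in several places, yet their values stay within the scatter of each other. On that limited basis, only a small step is expected in this assay, probably not beyond the scatter, with a slight lean toward a lower number. The expected change is a 1.4-fold lower number from compound 3 to compound 4 (0.14 log units; within the scatter). For compound 4 the estimated value is 3500 nM, with an expected range of 1500 nM to 8000 nM.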

Compound 4, half-maximal inhibitory concentration: 4500 nM
The estimate for compound 4 lay 1.3-fold (0.11 log units) below the measured number; the measured number falls inside the stated range.
By their numbers in this assay, from the lowest: compounds 1, 4, 3 and 2 (each within the scatter of the next).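

Among these compounds, this is the first comparison that differs in one place only, and in this assay it gives a 1.1-fold lower number from compound 3 to compound 4 (0.03 log units; within the scatter). Phenyl becoming 4-(trifluoromethyl)phenyl, which adds a group of 4 heavy atoms para to a large group, therefore leaves the number within the scatter, so this position tolerates trifluoromethyl in place of hydrogen in this assay without a readable gain or loss. No measurement is available that bears on what lies behind this result.

The compounds shown leave open whether a different group at the same place, such as an amine, a carboxylic acid or a longer chain, would move the number beyond the scatter, as a single substitution cannot show how far this tolerance extends. Among the compounds shown here, they also leave open whether trifluoromethyl would behave the same way with the other parts of compound 3 changed, as no second pair of compounds carries this same change.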